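A few compounds are considered here, and "the series" means these few. Any claim that something is new, unique, unknown or untested is made for them only; others in the source may bear on it.

Compound 1 `CC(C)(C)[C@@H](N)C(=O)NCc1ccc(OC(F)(F)F)cc1` was tested in a functional assay on the whole organism (strain albino Sprague-Dawley) with Rattus norvegicus as the target, in the maximal electroshock model (a lower number here means that less compound is needed, a higher number that more compound is needed for the effect), where compound 1 gives 23 mg/kg. Only compound 2 `COC[C@@H](N)C(=O)NCc1ccc(OCc2cccc(F)c2)cc1` offers a comparison: in this assay compound 2 gives 13 mg/kg, which lies within the usual scatter of the number for compound 1, so the two cannot be told apart. Compound 3 `CC(C)(C)[C@@H](N)C(=O)NCc1ccc(C(F)(F)F)cc1` differs from compound 1 in a single place: trifluoromethyl in place of trifluoromethoxy on an aromatic carbon. Among the compounds with values here, no measured pair shows this exchange, so the step of a 1.2-fold lower number from compound 1 to compound 3 (0.06 log units; within the scatter) is expected to stay within the scatter, with no clear direction. Compound 3 is accordingly estimated at 20 mg/kg, with a range from 8 mg/kg to 50 mg/kg.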

Compound 3, dose for half-maximal effect: < 30 mg/kg
Compound 3 was reported as a limit (the forecaster's own chance of this, stated with the estimate: 10%); the middle value lies beyond the limit too.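

In this assay, within the data shown here, compound 3 gives < 30 mg/kg, which is a limit and not a number, so no step from compound 1 to compound 3 can be read. The compounds shown leave open whether trifluoromethyl in place of trifluoromethoxy changes the required dose, and in which direction.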